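Moving the attachment of the methylindole

The compounds below may be only part of what the source reports. "The series", "measured", "known", "first", "only" and "open" are said of these compounds alone.

Measured so far in a functional assay on HCT-116 cells (Homo sapiens) for inhibition, read by CCK-8 assay, with a stated time of 48 h; a lower number here means a stronger inhibitor, a higher number a weaker inhibitor
compound 1 `COc1cc(-c2ccnc3cc(-c4ccc(C)cc4)nn23)cc(OC)c1OC` at 48 nM
compound 2 `COc1cc(-c2ccnc3cc(-c4ccc5cc[nH]c5c4)nn23)cc(OC)c1OC` at 187 nM
compound 3 `COc1cc(-c2ccnc3cc(-c4cn(C)c5ccccc45)nn23)cc(OC)c1OC` at 762 nM

In this assay compound 3 stands highest at 762 nM and is the weakest of the three. Compound 4 `COc1cc(-c2ccnc3cc(-c4ccc5ccn(C)c5c4)nn23)cc(OC)c1OC` differs from it by one change (1-methyl-1H-indol-6-yl in place of 1-methyl-1H-indol-3-yl on an aromatic carbon) and carries 1-methyl-1H-indol-6-yl in place of 1-methyl-1H-indol-3-yl. The closest evidence is the modest 4.1-fold higher number from compound 2 to compound 3 (0.61 log units; beyond the scatter) and the large 16-fold higher number from compound 1 to compound 3 (1.20 log units; beyond the scatter) sets the outer frame. The first of these also differs in the methyl, and the data do not separate the two parts. A modest fall in the number is therefore expected, undoing most of the first step. Expected for compound 4 is a 3.2-fold lower number from compound 3 to compound 4 (0.50 log units; beyond the scatter) in this assay as the likely size of the step. Compound 4 is estimated at 240 nM with a range from 90 nM to 600 nM as its expected span.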

Compound 4, half-maximal inhibitory concentration: 1040 nM
Beside the measured number, compound 4's estimate is 4.3-fold (0.64 log units) below it; measured number above the stated range.
By their numbers in this assay, from the lowest: compound 1; then compound 2; then compounds 3 and 4 (each within the scatter of the next).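

In this assay, moving the attachment from 1-methyl-1H-indol-3-yl to 1-methyl-1H-indol-6-yl gives a 1.4-fold higher number from compound 3 to compound 4 (0.14 log units; within the scatter), so the attachment point does not separate these two compounds. Within the data shown here, the methyl on the aromatic nitrogen, taken alone, gives a 5.6-fold higher number from compound 2 to compound 4 (0.75 log units; beyond the scatter), a step the earlier compounds left mixed with the change of attachment. Against the 4-methylphenyl group, the change gives a 22-fold higher number from compound 1 to compound 4 (1.34 log units; beyond the scatter) and stays well short of compound 1. No measurement shown explains these steps.

Open, going by these compounds, is whether an aminoethyl chain or a carboxylic acid in place of that methyl would restore the lower numbers in this assay.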